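From 4-fluorophenyl to furan-3-yl on the shared core

The source may hold more compounds than are shown below. What is called first, only, known or untested is meant among the compounds shown, and "the series" means these compounds.

For the measured compounds named here, in a functional assay on LN-229 cells (Homo sapiens) for antiproliferative activity, with a stated time of 72 h (a higher number here means a weaker inhibitor, a lower number a stronger inhibitor), compound 3 `Nc1ncnn2c([C@@H]3O[C@H](CO)[C@@H](O)[C@H]3O)cc(-c3ccc(F)cc3)c12` gives 65600 nM, the higher of the two actual numbers so far, while compound 1 `CCCC#Cc1cc([C@@H]2O[C@H](CO)[C@@H](O)[C@H]2O)n2ncnc(N)c12` gives 40 nM. For compound 2 `Nc1ncnn2c([C@@H]3O[C@H](CO)[C@@H](O)[C@H]3O)cc(C#Cc3cccs3)c12` only a limit is known, > 100000 nM. Compound 4 `Nc1ncnn2c([C@@H]3O[C@H](CO)[C@@H](O)[C@H]3O)cc(-c3ccoc3)c12` carries furan-3-yl in place of 4-fluorophenyl on an aromatic carbon. The two measured steps that bring in a ring were both large: a 1600-fold higher number from compound 1 to compound 3 (3.21 log units; beyond the scatter) and an at least 2500-fold higher number from compound 1 to compound 2 (3.39 log units; beyond the scatter). Going by the values given here, the one swap between ring-bearing groups, an at least 1.5-fold lower number from compound 2 to compound 3 (0.18 log units; that floor lies within the scatter), has a floor within the scatter. A modest move to a lower number is therefore expected, not a return to the level of compound 1. In this assay the estimated step is a 6.6-fold lower number from compound 3 to compound 4 (0.82 log units; beyond the scatter). For compound 4 the estimated value is 10000 nM, with an expected range of 300 nM to 100000 nM.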

Compound 4, half-maximal inhibitory concentration: 1000 nM
Estimate against measurement, compound 4: 10-fold (1.00 log units) above; measured number inside the range.
By their numbers in this assay, from the lowest: compound 1; then compound 4; then compound 3. At a limit, above all of these: compound 2.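

Ring choice at this place on the shared core matters far more than the earlier compounds could show, with furan-3-yl replacing 4-fluorophenyl giving a 66-fold lower number from compound 3 to compound 4 (1.82 log units; beyond the scatter). Compound 2 is known only as a limit: the limit of > 100000 nM in this assay, at which 1 of the 4 values shown sits. The step to furan-3-yl from the thiophene-bearing alkyne is still large, an at least 100-fold lower number from compound 2 to compound 4 (2.00 log units; beyond the scatter), yet furan-3-yl does not match pent-1-yn-1-yl, giving a 25-fold higher number from compound 1 to compound 4 (1.40 log units; beyond the scatter).

Still open, from the compounds shown here alone, is whether the gain follows ring size or the ring oxygen, which a plain phenyl or thiophen-3-yl group would help to separate. Going by these compounds, how a butyl chain on the triple bond or an amine at this place would compare also remains open.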